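Benzyl for chlorophenyl on thiourea and urea analogues

A few compounds are considered here, and "the series" means these few. Any claim that something is new, unique, unknown or untested is made for them only; others in the source may bear on it.

Compound 1 `CC1(C)CC(NC(=S)Nc2cccc(Cl)c2)c2cc(Br)ccc2O1` gives 9000 nM in a functional assay on T98G cells (Homo sapiens) for inhibition, read by MTT assay, with a stated time of 72 h; a higher number here means a weaker inhibitor, a lower number a stronger inhibitor. Compound 2 `CC1(C)CC(NC(=S)NCc2ccccc2)c2cc(Br)ccc2O1` carries benzyl in place of 3-chlorophenyl on an amide-type nitrogen and gives 54000 nM in this assay; the step is a 6.0-fold higher number from compound 1 to compound 2 (0.78 log units; beyond the scatter). Compound 3 `CC1(C)CC(NC(=O)Nc2cccc(Cl)c2)c2cc(F)ccc2O1` gives 45000 nM in this assay, a number within the scatter of compound 2 and beyond the scatter from compound 1. The difference between the cores of compound 1 and compound 3 is not broken down here. Compound 4 `CC1(C)CC(NC(=O)NCc2ccccc2)c2cc(F)ccc2O1` is not yet measured; it carries benzyl in place of 3-chlorophenyl on an amide-type nitrogen. This is the same kind of change as between compound 1 and compound 2, though the place is not identical: in compound 3 the other neighbour of the amide-type nitrogen is a carbonyl carbon, in compound 1 a thiocarbonyl carbon. Because a 6.0-fold higher number from compound 1 to compound 2 (0.78 log units; beyond the scatter) was seen, compound 4 is expected to show a 5.6-fold higher number from compound 3 to compound 4 (0.74 log units; beyond the scatter) in this assay. Compound 4 is estimated at 250000 nM, between 80000 nM and 700000 nM, with a real chance that only a limit is returned.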

Compound 4, half-maximal inhibitory concentration: 49000 nM
Estimate against measurement, compound 4: 5.1-fold (0.71 log units) above; the measured number lies below the stated range.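

In this assay, benzyl in place of 3-chlorophenyl on an amide-type nitrogen gives a 1.1-fold higher number from compound 3 to compound 4 (0.04 log units; within the scatter), so the change does not carry over at one size between these two cores: the same change on two cores in this assay, a 6.0-fold higher number (0.78 log units; beyond the scatter) from compound 1 to compound 2 and a 1.1-fold higher number (0.04 log units; within the scatter) from compound 3 to compound 4, 5.5-fold (0.74 log units) apart, beyond the scatter of two such steps

This shows that the size of the step depends on the core in these two pairs. It does not show which part of the difference between the core of compound 1 and the core of compound 3 matters, as the thiocarbonyl carbon and carbonyl carbon are not separated from the rest of that difference.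

Still open, on these data alone, is how a 3-chlorobenzyl or an unsubstituted phenyl group would read on each core. Such groups would separate the chlorine from the extra carbon of benzyl.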